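From hydroxy to chloro on the shared core

The source may hold more compounds than are shown below. What is called first, only, known or untested is meant among the compounds shown, and "the series" means these compounds.

- Compound 1 `Cn1ncc2c(NC3(c4ccc(C(F)(F)F)cc4)CC3)nc(O)nc21`: 175000 nM
- Compound 2 `Cn1ncc2c(NCc3ccccc3Cl)nc(Cl)nc21`: 44000 nM
- Compound 3 `Cn1ncc2c(N3CCCCC3c3ccc(C(F)(F)F)cc3)nc(Cl)nc21`: 138000 nM

In a physicochemical assay for solubility, at pH 6.5 (on this read-out lower numbers stand for lower solubility and higher numbers for higher solubility), compound 1 gives 175000 nM. This lies within the scatter of compound 3 and beyond the scatter above compound 2.

Compound 4 `Cn1ncc2c(NC3(c4ccc(C(F)(F)F)cc4)CC3)nc(Cl)nc21`, not yet measured, has chloro in place of hydroxy on an aromatic carbon, between two ring nitrogen atoms (chloro in place of hydroxy on an aromatic carbon). Among the compounds with values here, no measured pair isolates this change. Within the data shown here, the two chloro compounds offer the only guide, with compound 2 at 44000 nM and compound 3 at 138000 nM. A moderate downward step is therefore expected, estimated as a 2.9-fold lower number from compound 1 to compound 4 (0.46 log units; beyond the scatter). For compound 4 the expected value in this assay is 60000 nM, with an estimated range of 18000 nM to 170000 nM.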

Compound 4, solubility: 156000 nM
The estimate for compound 4 lay 2.6-fold (0.41 log units) below the measured number; low and high end bracket the measured number.
By their numbers in this assay, from the lowest: compound 2; then compounds 3, 4 and 1 (each within the scatter of the next).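

In this assay, the first pair differing in one place shows that chloro in place of hydroxy on an aromatic carbon, between two ring nitrogen atoms, gives a 1.1-fold lower number from compound 1 to compound 4 (0.05 log units; within the scatter). On this shared core, therefore, the read-out does not separate the two groups at this position. Nothing available explains why they read alike.

From the compounds shown here alone, whether an amine or a methoxy group on this carbon would also stay within the scatter of compound 1 remains open. So does whether this change reads the same with the other groups carried by compound 2 and compound 3.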